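Swapping a chain methyl for hydroxy in an alpha-1 ligand

The compounds below may be only part of what the source reports. "The series", "measured", "known", "first", "only" and "open" are said of these compounds alone.

Measured so far:
compound 1, `Oc1ccc(C(O)CCN2CCC(Cc3ccccc3)CC2)cc1`, 24.4 nM
compound 2, `CC(Cc1ccc(O)cc1)CN1CCC(Cc2ccccc2)CC1`, 91.5 nM

Both were tested in an assay on isolated protein for binding affinity to Adrenergic receptor alpha-1 (Homo sapiens), read by radioligand binding; a lower number here means a stronger inhibitor, a higher number a weaker inhibitor. Compound 2 stands at the higher of the two numbers, the weaker inhibitor, and its gap to compound 1 lies beyond the usual scatter. Compound 3, `Oc1ccc(CC(O)CN2CCC(Cc3ccccc3)CC2)cc1`, has not been measured. It differs from compound 2 in one place: hydroxy in place of methyl on a saturated chain carbon bound to two saturated chain carbons. Within the data shown here, no step of this exact kind is known from the measured pair, so the expectation rests on compound 1, which carries a hydroxy on its chain and gives 24.4 nM. A moderate step toward a lower number is expected, a 2.3-fold lower number from compound 2 to compound 3 (0.36 log units; beyond the scatter). Compound 3 is therefore estimated at 40 nM, within a range from 15 nM to 120 nM.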

Compound 3, inhibition constant: 305 nM
For compound 3 the middle estimate is 7.6-fold (0.88 log units) below the measured one; measured number outside the range, above it.
By their numbers in this assay, from the lowest: compound 1; then compound 2; then compound 3.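

On a saturated chain carbon bound to two saturated chain carbons, hydroxy in place of methyl weakens the compound in this assay, with a 3.3-fold higher number from compound 2 to compound 3 (0.52 log units; beyond the scatter) as the measured step. At this position, then, methyl is the better of the two groups, and the gap lies beyond the usual scatter. Nothing measured here explains why the number rises. Going by these compounds, what remains open is how other groups would fare at this position, such as an amine, a methoxy group or plain hydrogen. A single step cannot show whether methyl is itself favourable or hydroxy is simply unfavourable there.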